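Halogenated phenoxypropyl series: inhibition of human dihydrofolate reductase

The source may report more compounds than this note shows. Statements on the series, on what has been measured and on what is new or still open speak of the compounds shown alone.

Working notes on three compounds sharing one core and a three-carbon oxygen-linked tether to a halogenated phenyl ring. In an assay on isolated protein for inhibition of Dihydrofolate reductase (Homo sapiens), read by spectrophotometry, using NADPH, with stated times of 5 s and 6 min, tested at 50 uM (on this read-out lower numbers stand for a weaker effect and higher numbers for a stronger effect at the one concentration tested), compound 1 `NC1=NC2(CCSCC2)N(OCCCOc2ccc(Br)cc2)C(N)=N1` gives "not determined" (no result reported); nothing was determined for it. Compound 2 `NC1=NC2(CCOCC2)N(OCCCOc2cccc(Cl)c2Cl)C(N)=N1` is therefore the only compound with a number: in this assay compound 2 gives 89.8%, and it stands alone at the top of what is shown, with no second value against which to place it.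

Compound 3 `NC1=NC2(CCOCC2)N(OCCCOc2cccc(Br)c2)C(N)=N1` has not yet been measured in this assay. The change from compound 2 to compound 3 is 3-bromophenyl in place of 2,3-dichlorophenyl on an oxygen on a saturated carbon. No step between two measured compounds is shown for this series, so there is no measured pair from which to read the size of such a change. The expectation is a small downward step from compound 2 to compound 3, of about a number 9.8 percentage points lower from compound 2 to compound 3 (within the scatter) in this assay, close to or within the usual scatter. Compound 3 is accordingly expected to give about 80% in this assay, estimated to fall between 55% and 95%.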

Compound 3, a percentage reported as inhibition, at one concentration (the size of the read-out at that concentration, not a potency): 85.8%
Beside the measured number, compound 3's estimate is 5.8 percentage points below it; measured number inside the range.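

Among the compounds shown here, the first measured pair gives a direct reading at this position: in this assay, 3-bromophenyl in place of 2,3-dichlorophenyl on an oxygen on a saturated carbon gives a number 4 percentage points lower from compound 2 to compound 3 (within the scatter), so the two compounds cannot be told apart on this read-out. For the compounds shown here, the exchange of these two halogenated phenyl groups, with their different halogens and substitution, therefore has no effect that can be separated from the scatter at the one concentration tested, although this single pair shows nothing about other groups at this position and, as a single-concentration reading, gives no potency for either compound. Nothing on hand accounts for this result or ties it to any property of either group.

The compounds shown leave open whether this position accepts something other than a halogenated phenyl ring, such as an unsubstituted phenyl ring, a pyridine ring or a phenyl ring bearing a carboxylic acid or an amine. They also leave open how the read-out responds to a longer chain between the shared core and the ring, and whether a full concentration series would separate compound 2 from compound 3.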